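Methyl on a ring nitrogen: compound 2 to compound 4

The compounds below may be only part of what the source reports. "The series", "measured", "known", "first", "only" and "open" are said of these compounds alone.

Measured so far in a physicochemical assay for solubility, measured as kinetic solubility, at pH 2; on this read-out higher numbers stand for higher solubility and lower numbers for lower solubility:
- compound 1 `CC(C)[C@@H](c1ccc(-c2ccc3cccc(F)c3c2)[nH]c1=O)[C@@H]1OC(=O)NC1=O`: 6900 nM
- compound 2 `CC(C)C(c1ccc(-c2ccc3cccc(F)c3c2)[nH]c1=O)C1NC(=O)NC1=O`: 5800 nM
- compound 3 `CCn1ncc2c(F)cc(-c3ccc(C(/C=C4\OC(=O)NC4=O)(CC)CC)c(=O)[nH]3)cc21`: 21700 nM

In this assay, compound 2 at 5800 nM lies within the scatter of compound 1 at 6900 nM. Compound 3 at 21700 nM stands higher than compound 2, and that gap lies beyond the scatter.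

The next compound to be read is compound 4 `CC(C)C(c1ccc(-c2ccc3cccc(F)c3c2)[nH]c1=O)C1C(=O)NC(=O)N1C`. It differs from compound 2 in one place: methyl in place of hydrogen on an amide-type nitrogen in a ring. This is methyl in place of hydrogen on an amide-type nitrogen in a ring, on the ring nitrogen next to the ring atom that bears a large group.

For the measured compounds named here, no two measured compounds here differ in one place, so the set offers no direct measure of this change. Three values are too few to support a trend in either direction. The expectation therefore starts from compound 2 at 5800 nM, and no shift beyond the scatter is anticipated in this assay. The estimated step is a 1.0-fold higher number from compound 2 to compound 4 (0.01 log units; within the scatter), with no clear direction.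

For compound 4 the expected value is 6000 nM, with an estimated range of 2200 nM to 16000 nM.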

Compound 4, solubility: 13600 nM
Estimate against measurement, compound 4: 2.3-fold (0.36 log units) below; measured number inside the range.
By their numbers in this assay, from the lowest: compounds 2, 1, 4 and 3 (each within the scatter of the next, the first and the last beyond it).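

In this assay, a 2.3-fold higher number from compound 2 to compound 4 (0.37 log units; beyond the scatter) gives the series its first comparison of compounds that differ in one place, and it reads as a rise beyond the scatter. Before this pair, the values gave no measure of what this ring nitrogen contributes; now methyl in place of the amide hydrogen, on the nitrogen next to the ring atom that bears a large group, is tied to a modest upward move, so this read-out does not fall when that hydrogen is lost. No supporting measurement bears on why the number moves, so the step stands as an observation on a single pair.

Still open, going by these compounds, is whether the step is particular to methyl, or whether an ethyl group, a longer chain or a chain ending in an amine on this same nitrogen would carry it further, hold it or reverse it. Also open, on these data alone, is how the same methyl would read on the other ring nitrogen, and whether a compound bearing methyl on both ring nitrogens would add to this step.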